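A few compounds are considered here, and "the series" means these few. Any claim that something is new, unique, unknown or untested is made for them only; others in the source may bear on it.

Compound 2, `COc1cc(-c2nnc(SCC(=O)c3ccc(F)cc3)n2N)cc(OC)c1OC`, belongs to a small set built on a shared core. In a functional assay on HepG2 cells (Homo sapiens) for antiproliferative activity, read by MTT assay, with a stated time of 48 h (a higher number here means a weaker inhibitor, a lower number a stronger inhibitor), compound 2 gives 90400 nM, the lowest of the two numbers shown, though its nearest neighbour compound 1, `COc1cc(-c2nnc(SCC(=O)c3ccc(Br)cc3)n2N)cc(OC)c1OC`, gives 92500 nM in this assay, and a 1.0-fold lower number from compound 1 to compound 2 (0.01 log units; within the scatter). Compound 3, `COc1cc(-c2nnc(SCC(=O)Nc3ccccc3C)n2N)cc(OC)c1OC`, gives only a limit of the assay in this assay, > 100000 nM. The limit is the one noted as the limit of > 100000 nM in this assay, at which 1 of the 3 values shown sits.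

The step to compound 4, `COc1cc(-c2nnc(SCC(=O)NCc3ccc(Cl)cc3)n2N)cc(OC)c1OC`, changes compound 2 in one place: (4-chlorobenzyl)amino in place of 4-fluorophenyl on a carbonyl carbon. The measured steps that bear on it are those in which an amino group replaced an aryl group on the carbonyl carbon: an at least 1.1-fold higher number from compound 2 to compound 3 (0.04 log units; that floor lies within the scatter), and an at least 1.0-fold higher number from compound 1 to compound 3 (0.03 log units; that floor lies within the scatter). Both ended at the limit, so no size can be read from them beyond the floor they set. For compound 4 in this assay the step of a 1.2-fold higher number from compound 2 to compound 4 (0.09 log units; within the scatter) is therefore expected, with a fair chance that only a limit is reported again. Compound 4 is estimated at 110000 nM in this assay, within 60000 nM to 200000 nM.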

Compound 4, half-maximal inhibitory concentration: > 100000 nM
Compound 4: only a limit was reported; the forecaster's own chance of this, stated with the estimate: 55%; the middle value does not contradict the limit.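

Compound 4 places a second, different amino group on the carbonyl carbon, and in this assay it too gives only a limit, as compound 3 does: the limit of > 100000 nM in this assay, at which 2 of the 4 values shown sit. Against the aryl compounds the readable steps are an at least 1.1-fold higher number from compound 2 to compound 4 (0.04 log units; that floor lies within the scatter) and an at least 1.0-fold higher number from compound 1 to compound 4 (0.03 log units; that floor lies within the scatter); these are floors only, so neither shows a real loss. The step between compound 3 and compound 4 cannot be read, so the 4-chlorobenzyl and 2-methylphenyl groups on the amide-type nitrogen cannot be ranked.

The compounds shown leave open whether any group on this carbonyl carbon can bring the number clearly below that of compound 2. A morpholine amide or a carboxylic acid at this place would test that, as would a longer chain between the amide-type nitrogen and the ring.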